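This account rests on a few compounds, and the source may have more. Where it says the series, first, only, none or still open, it means among the compounds named here.

Measured compounds:
compound 1 `c1ccc(-c2cn3ccnc3c(-c3ccc4ncn(C5CCCCC5)c4c3)n2)cc1` — 59.5% in a functional assay on HCT-116 cells (Homo sapiens) for inhibition, read by sulforhodamine B assay, with a stated time of 48 h, tested at 10 uM; on this read-out lower numbers stand for less inhibition and higher numbers for more inhibition at the one concentration tested (going by the name of the read-out)
compound 2 `c1ccc2c(-c3cn4ccnc4c(-c4ccc5ncn(C6CCCCC6)c5c4)n3)cccc2c1` — 17.9% in this assay

Among the compounds with values here, compound 2 stands at the lower of the two numbers in this assay; the only other compound measured, compound 1, sits a number 41.6 percentage points lower from compound 1 to compound 2 (beyond the scatter) above it, a step in which a naphthalen-1-yl took the place of phenyl on an aromatic carbon. Compound 3 `c1ccc(Cn2cnc3ccc(-c4nc(-c5cccc6ccccc56)cn5ccnc45)cc32)cc1` departs from compound 2 at a different site: benzyl in place of cyclohexyl on an aromatic nitrogen. Within the data shown here, no measured pair changes the substituent on that ring nitrogen, so the single step on record bears on a different part of the shared core and gives no direct guidance here. With nothing in the data pointing either way, the expected step is one within the scatter: a number 2.1 percentage points higher from compound 2 to compound 3 (within the scatter). Compound 3 is therefore estimated at 20% in this assay, with a range of 5% to 45%, the width reflecting the lack of any comparable measured change.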

Compound 3, a percentage reported as inhibition, at one concentration (the size of the read-out at that concentration, not a potency): 32.9%
The estimate for compound 3 lay 12.9 percentage points below the measured number; the range from low to high includes it.
By their numbers in this assay, from the lowest: compound 2; then compound 3; then compound 1.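

In this assay, the substituent on the aromatic nitrogen also moves the read-out: with naphthalen-1-yl held fixed, benzyl in place of cyclohexyl gives a number 15 percentage points higher from compound 2 to compound 3 (beyond the scatter), a modest step. Within the data shown here, the earlier step concerned a different site, so this is the first measured sign that this ring nitrogen is not a silent position, and here the aromatic benzyl ring reads higher than the non-aromatic cyclohexyl ring. No measurement on hand accounts for the difference between these two groups.

Whether benzyl gives a similar step with phenyl in place of naphthalen-1-yl remains open, since the compounds shown pair benzyl only with naphthalen-1-yl. Also open, on these data alone, is how a longer chain such as 2-phenylethyl, or a dimethylaminoethyl amine, would read on that nitrogen.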